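Trimethoxystilbene ethers: aryl-butenyl side chain variation

The source may report more compounds than this note shows. Statements on the series, on what has been measured and on what is new or still open speak of the compounds shown alone.

Three analogues sharing one stilbene core have been run in a functional assay on MCF7 cells (Homo sapiens) for inhibition, read by MTT assay, with a stated time of 3 days; a higher number here means a weaker inhibitor, a lower number a stronger inhibitor. Compound 1 `COc1ccc(COc2cc(/C=C\c3cc(OC)c(OC)c(OC)c3)ccc2OC)cc1` gives 48000 nM in this assay. Compound 2 `COc1cccc(/C=C/CCCOc2cc(/C=C\c3cc(OC)c(OC)c(OC)c3)ccc2OC)c1` gives 41000 nM, and compound 3 `COCOc1cccc(/C=C/CCCOc2cc(/C=C\c3cc(OC)c(OC)c(OC)c3)ccc2OC)c1` gives 8000 nM. Compound 2 stands with compound 1, the step of a 1.2-fold lower number from compound 1 to compound 2 (0.07 log units; within the scatter) lying within the scatter, while the step of a 5.1-fold lower number from compound 2 to compound 3 (0.71 log units; beyond the scatter) sets compound 2 apart from compound 3, which holds the lowest number of the three.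

Compound 4 `COc1ccc(/C=C\c2cc(OC)c(OC)c(OC)c2)cc1OCCC/C=C/c1ccc(Br)cc1` is the next member. Relative to compound 2 the change is 4-bromophenyl in place of 3-methoxyphenyl on a double-bonded chain carbon bound to a double-bonded chain carbon. Of the measured steps, a 1.2-fold lower number from compound 1 to compound 2 (0.07 log units; within the scatter) exchanged the whole side group without effect beyond the scatter, and a 5.1-fold lower number from compound 2 to compound 3 (0.71 log units; beyond the scatter) altered only the substituent on the terminal ring, with a modest gain. Neither step copies the present exchange of 3-methoxyphenyl for 4-bromophenyl, so no firm direction follows; the terminal ring substituent has mattered once, in a 5.1-fold lower number from compound 2 to compound 3 (0.71 log units; beyond the scatter), so some movement is possible.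

The estimate for compound 4 is 35000 nM, between 8000 nM and 150000 nM, a step of a 1.2-fold lower number from compound 2 to compound 4 (0.07 log units; within the scatter) that is expected to stay near compound 2.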

Compound 4, half-maximal inhibitory concentration: 37000 nM
The estimate for compound 4 lay 1.1-fold (0.02 log units) below the measured number; the measured number falls inside the stated range.
By their numbers in this assay, from the lowest: compound 3; then compounds 4, 2 and 1 (each within the scatter of the next).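

In this assay the place on a double-bonded chain carbon bound to a double-bonded chain carbon accepts 4-bromophenyl for 3-methoxyphenyl with no reading beyond the scatter: a 1.1-fold lower number from compound 2 to compound 4 (0.04 log units; within the scatter). A terminal ring with bromine and no hydrogen-bond acceptor therefore reads like one with a methoxy group, and the longer bromophenyl side group also reads like the side group of compound 1: a 1.3-fold lower number from compound 1 to compound 4 (0.11 log units; within the scatter). The 3-(methoxymethoxy)phenyl ring remains the only one shown that separates from the others, as a 4.6-fold higher number from compound 3 to compound 4 (0.67 log units; beyond the scatter) confirms, and nothing available bears on the reason.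

As far as these compounds go, whether the separation of compound 3 belongs to the methoxymethoxy group itself or to its place on the ring remains open. A hydroxy group, an amine or a carboxylic acid on the terminal ring, or a longer chain, remains untested in the compounds shown.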